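Benzyl for tert-Butoxycarbonyl on a Bridged Ring Amine

The compounds below may be only part of what the source reports. "The series", "measured", "known", "first", "only" and "open" are said of these compounds alone.

Of the compounds shown here, two with a shared core have so far been tested in a functional assay on HEK293 cells for agonist activity at Glucose-dependent insulinotropic receptor (Homo sapiens), read by cAMP accumulation, with a stated time of 60 min; on this read-out higher numbers stand for larger maximal responses and lower numbers for smaller maximal responses. Compound 1 `COc1cc2nc(N3CCC4CCC(C3)N4C(=O)OC(C)(C)C)nc(Nc3ccc(S(C)(=O)=O)cc3F)c2cc1OC` gives 56.9% in this assay, the higher of the two numbers seen so far. Compound 2 `COc1cc2nc(Nc3ccc(S(C)(=O)=O)cc3F)nc(OC3CCN(C(=O)OC(C)(C)C)CC3)c2cc1OC` gives 19.7% in this assay, a number that lies beyond the usual scatter below compound 1; since the two differ in more than one place, only the values themselves can be compared. Compound 3 `COc1cc2nc(N3CCC4CCC(C3)N4Cc3ccccc3)nc(Nc3ccc(S(C)(=O)=O)cc3F)c2cc1OC` has not yet been measured. It comes from compound 1 through one change: benzyl in place of tert-butoxycarbonyl on an amine nitrogen in a ring. For the measured compounds named here, no measured pair shows what such a swap does here, so the direction of the step is open; a moderate step either way, or none beyond the scatter, seems equally plausible. Compound 3 is estimated at 50% in this assay, within a range from 25% to 78%. That estimate means an expected step of a number 6.9 percentage points lower from compound 1 to compound 3 (within the scatter).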

Compound 3, largest response reached (Emax), in percent of the reference or control that the assay uses: 44.3%
For compound 3 the middle estimate is 5.7 percentage points above the measured one; the measured number falls inside the stated range.
By their numbers in this assay, from the lowest: compound 2; then compound 3; then compound 1.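

For the compounds shown here, this is the first direct reading of this position: in this assay, placing benzyl instead of tert-butoxycarbonyl on the amine nitrogen gives a number 12.6 percentage points lower from compound 1 to compound 3 (beyond the scatter) as a modest step. Compound 3 still gives 44.3% of response with a group that has an aromatic ring and no oxygen, so the oxygens of tert-butoxycarbonyl are not required for a response of this order, although the swap does lower it. No measurement available here explains the direction or size of this step.

The compounds shown leave open what a much smaller group on this nitrogen, such as methyl, or the free amine bearing only a hydrogen would do. They also leave open whether benzyl would produce a similar step on the ring amine of compound 2.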